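The source may report more compounds than this note shows. Statements on the series, on what has been measured and on what is new or still open speak of the compounds shown alone.

Measured in an ADME assay on MRC5 cells (Homo sapiens) for cytotoxicity, read by neutral red uptake; on this read-out higher numbers stand for lower toxicity in this test and lower numbers for higher toxicity in this test:

- compound 1 `O=c1[nH]c(SCc2ccccc2Cl)nc2ccccc12`: > 65000 nM
- compound 2 `O=c1[nH]c(SCc2c([N+](=O)[O-])cccc2[N+](=O)[O-])nc2ccccc12`: > 64000 nM
- compound 3 `O=c1[nH]c(SCc2cc([N+](=O)[O-])cc([N+](=O)[O-])c2)nc2ccc(Cl)cc12`: > 64000 nM

Each of these three entries is a limit of the assay and not a number.

Compound 3 stands at > 64000 nM as a limit, so the starting point of the step is not an exact value. Compound 4 `CN1CCN(c2ccc3nc(SCc4cc([N+](=O)[O-])cc([N+](=O)[O-])c4)[nH]c(=O)c3c2)CC1` carries 4-methylpiperazin-1-yl in place of chloro on an aromatic carbon, a change counted as 4-methylpiperazin-1-yl in place of chloro on an aromatic carbon in this comparison. Among the measured compounds shown here, no measured pair of compounds shows what a single change does in this assay, so the expectation remains loose. The expected change is modest and points toward lower numbers, which would mean higher toxicity in this test. The estimate is an at least 1.8-fold lower number from compound 3 to compound 4 (0.26 log units; that floor lies within the scatter) and could prove too large, as compound 4 may also return only a limit. For compound 4 the estimated value is 35000 nM with an expected range from 9000 nM to 64000 nM in the same read-out.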

Compound 4, half-maximal cytotoxic concentration: 49000 nM
Beside the measured number, compound 4's estimate is 1.4-fold (0.15 log units) below it, within the range that was stated.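

In this assay compound 4 gives 49000 nM, the only exact value among the four shown, so 4-methylpiperazin-1-yl in place of chloro, at a position para to a fused ring, brings the read-out within measurable range. The change amounts to an at least 1.3-fold lower number from compound 3 to compound 4 (0.11 log units; that floor lies within the scatter). Compound 3 is a limit and not a number, so this step can be read only as a floor: the limit of > 64000 nM in this assay, at which 2 of the 4 values shown sit.

On these data alone, how far the true step extends beyond that floor remains open. Also open, as far as these compounds go, is whether a morpholin-4-yl group, an open-chain dimethylamino group or a carboxylic acid at the same position would return a number or only a limit in this assay.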